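The source may hold more compounds than are shown below. What is called first, only, known or untested is meant among the compounds shown, and "the series" means these compounds.

Measured compounds:
compound 1 `O=C(Nc1ccc(Oc2ccnc3[nH]ccc23)cc1)c1cn(-c2ccccc2)c2ccccc2c1=O` — in a functional assay on MCF7 cells (Homo sapiens) for inhibition, read by MTT assay, with a stated time of 72 h (a higher number here means a weaker inhibitor, a lower number a stronger inhibitor), compound 1 gives 3560 nM
compound 2 `O=C(Nc1ccc(Oc2ccnc3[nH]ccc23)cc1)c1cn(-c2ccc(F)cc2)c2ccccc2c1=O` — in this assay compound 2 gives 720 nM
compound 3 `O=C(Nc1ccc(Oc2ccnc3[nH]ccc23)cc1)c1cn(-c2ccc(Br)cc2F)c2ccccc2c1=O` — in this assay compound 3 gives "not determined" (no result reported)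

Compound 3 stands nowhere on the numbers: its run in this assay returned no value, so it offers no anchor of its own. Compound 4 `O=C(Nc1ccc(Oc2ccnc3[nH]ccc23)cc1)c1cn(-c2ccc(F)c(Cl)c2)c2ccccc2c1=O` differs from it by 3-chloro-4-fluorophenyl in place of 4-bromo-2-fluorophenyl on an aromatic nitrogen. Going by the values given here, the only measured step, a 4.9-fold lower number from compound 1 to compound 2 (0.69 log units; beyond the scatter), concerns a single halogen entering an otherwise bare ring on the aromatic nitrogen and does not test a rearrangement of two halogens, so it bears on the present change only loosely. Since compound 4 keeps a fluorine on that ring, as compound 2 does with 720 nM, a number in the neighbourhood of compound 2 is expected, with wide uncertainty. Compound 4 is expected at 650 nM, range 200 nM to 2500 nM.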

Compound 4, half-maximal inhibitory concentration: 1510 nM
Compound 4: the middle estimate sits 2.3-fold (0.37 log units) below what was measured, within the range that was stated.
By their numbers in this assay, from the lowest: compound 2; then compound 4; then compound 1.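

In this assay chloro added to the 4-fluorophenyl ring gives back part of what fluoro alone gained (a 2.1-fold higher number from compound 2 to compound 4 (0.32 log units; beyond the scatter)), yet the 3-chloro-4-fluorophenyl compound still keeps an edge over the bare phenyl (a 2.4-fold lower number from compound 1 to compound 4 (0.37 log units; beyond the scatter)). On this ring a second halogen therefore did not add to the first, and potency does not follow halogen count across these compounds. No measured evidence bears on this result.

The step from compound 3 to compound 4 cannot be read. On these data alone, whether a methoxy group or an amine at the chloro position would fare better remains open.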